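A few compounds are considered here, and "the series" means these few. Any claim that something is new, unique, unknown or untested is made for them only; others in the source may bear on it.

Measured in a physicochemical assay for solubility, in phosphate buffer, at pH 7.4; on this read-out lower numbers stand for lower solubility and higher numbers for higher solubility:
- compound 1 `CC(=O)N[C@@H]1CCC[C@H](C(=O)Nc2cc(-c3cnc(C)n3C(C)C)ccn2)C1`: 660000 nM
- compound 2 `CC(=O)N[C@@H]1CCC[C@H](C(=O)Nc2cc(-c3nnn4ccccc34)c(Cl)cn2)C1`: 530000 nM

Only these two compounds have been measured in this assay, and their values lie within the usual scatter of each other, so compound 2 cannot be separated from compound 1 on these numbers. Compound 3 `CC(=O)N[C@@H]1CCC[C@H](C(=O)Nc2cc(-c3cnn4c3OCCC4)c(Cl)cn2)C1` is compound 2 with one group exchanged, ortho to a chloro group: a group of 9 heavy atoms (6 carbon, 2 nitrogen, 1 oxygen; one five-membered aromatic ring with 2 hetero atoms, one six-membered non-aromatic ring with 2 hetero atoms) in place of a group of 9 heavy atoms (6 carbon, 3 nitrogen; one five-membered aromatic ring with 3 hetero atoms, one six-membered aromatic ring with 1 hetero atom), on an aromatic carbon. Within the data shown here, no measured pair of compounds shows what a single change of this kind does. The expectation therefore starts from compound 2 at 530000 nM, and the estimated step of a 1.1-fold lower number from compound 2 to compound 3 (0.03 log units; within the scatter) is expected to stay within the scatter. For compound 3 the expected value is 500000 nM, with an estimated range from 200000 nM to 1000000 nM.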

Compound 3, solubility: 110000 nM
Estimate against measurement, compound 3: 4.5-fold (0.66 log units) above, outside the stated range (below it).
By their numbers in this assay, from the lowest: compound 3; then compounds 2 and 1 (each within the scatter of the next).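

The exchange on this aromatic carbon, ortho to a chloro group, gives a 4.8-fold lower number from compound 2 to compound 3 (0.68 log units; beyond the scatter) in this assay. This shows that the read-out at this position can move beyond the scatter even though the leaving and entering groups match in heavy atoms, hydrogen-bond donors, hydrogen-bond acceptors and net charge, so those counts alone do not settle the value for this pair. No measurement at hand accounts for the step.

The exchange alters the ring make-up, the oxygen and the nitrogen count all at once, so the compounds shown cannot tell which of these differences matters. From the compounds shown here alone, it also remains open how the value would respond to a group carrying an amine or a carboxylic acid on this same carbon.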